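The source may hold more compounds than are shown below. What is called first, only, known or untested is meant among the compounds shown, and "the series" means these compounds.

Measured in a functional assay on B16-F10 cells (Mus musculus) for cytotoxicity; a lower number here means a stronger inhibitor, a higher number a weaker inhibitor:
Compound 1 `O=c1oc2ccccc2c2nc3c(ccc4cc[nH]c43)c(-c3ccc(Br)cc3)c12` gives 70700 nM.
Compound 2 `O=c1oc2ccccc2c2nc3c(ccc4cc[nH]c43)c(-c3ccc(F)cc3)c12` gives 70700 nM.
Compound 3 `O=c1oc2ccccc2c2nc3c(ccc4cc[nH]c43)c(-c3cccc(Cl)c3Cl)c12` gives 70700 nM.

Compound 3 stands level with compounds 1 and 2 in this assay: the steps of no change at the digits printed from compound 1 to compound 3 (within the scatter) and no change at the digits printed from compound 2 to compound 3 (within the scatter) both lie within the scatter, as does no change at the digits printed from compound 1 to compound 2 (within the scatter). Compound 4 `Cc1ccc(-c2c3ccc4cc[nH]c4c3nc3c2c(=O)oc2ccccc23)cc1` differs from compound 3 in one place: 4-methylphenyl in place of 2,3-dichlorophenyl on an aromatic carbon. Each of the three measured steps bears on this change, since each also exchanges one substituted phenyl for another on that aromatic carbon, and none of them moved the read-out beyond the scatter. A step of the same kind, that is none beyond the scatter, is therefore expected here, no change at the digits printed from compound 3 to compound 4 (within the scatter). Compound 4 is accordingly estimated at 70700 nM, with a range from 30000 nM to 120000 nM.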

Compound 4, half-maximal inhibitory concentration: 70700 nM
The estimate for compound 4 equals the measured number at the digits printed, and the stated range covers the measured number.
By their numbers in this assay, from the lowest: compounds 1, 2, 3 and 4 (each within the scatter of the next).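

In this assay, compound 4 puts a carbon-only 4-methylphenyl on an aromatic carbon so far held by halogen-bearing phenyl groups, and the result is level (no change at the digits printed from compound 3 to compound 4 (within the scatter)). Methyl in place of fluoro (no change at the digits printed from compound 2 to compound 4 (within the scatter)) and methyl in place of bromo (no change at the digits printed from compound 1 to compound 4 (within the scatter)) read the same, so among these four compounds a halogen on this phenyl is not required for the level seen. From the compounds shown here alone, whether a phenyl carrying an amine or a carboxylic acid, or a longer chain on this carbon, would depart from that level remains open. No supporting evidence is available to explain this flat result.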